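Pyrazole chain-end groups: working notes on the series

A few compounds are considered here, and "the series" means these few. Any claim that something is new, unique, unknown or untested is made for them only; others in the source may bear on it.

Measured so far in a functional assay on DU-145 cells (Homo sapiens) for inhibition, read by sulforhodamine B assay, with a stated time of 48 h; a lower number here means a stronger inhibitor of growth, a higher number a weaker inhibitor of growth:
compound 1 `CCCCCCCCCCCC[C@@H](O)[C@H]1CC[C@H]([C@H](O)CCCCCCCCCCN(C)C(=O)c2ccnn2C)O1` gives 12900 nM
compound 2 `CCCCCCCCCCCC[C@@H](O)[C@H]1CC[C@H]([C@H](O)CCCCCCCCCCNCc2ccnn2C)O1` gives 4370 nM

Of the two, compound 2 holds the lower number, at 4370 nM in this assay and so the stronger growth inhibition. The next case is compound 3 `CCCCCCCCCCCC[C@@H](O)[C@H]1CC[C@H]([C@H](O)CCCCCCCCCCOC(=O)c2ccnn2C)O1` and the change from compound 2 is ((1-methyl-1H-pyrazol-5-yl)carbonyl)oxy in place of ((1-methyl-1H-pyrazol-5-yl)methyl)amino on a saturated chain carbon, ten or more bonds along the chain from an oxygen on a saturated carbon and a saturated ring carbon with the rest of the structure unchanged. Among the measured compounds shown here, only one measured step bears on this, a 3.0-fold lower number from compound 1 to compound 2 (0.47 log units; beyond the scatter) and it is modest. That step concerns a change at the same chain end. Compound 3 carries a carbonyl there, as does compound 1 at 12900 nM on the same chain, and compound 2 has none. A step of similar modest size towards a higher number is therefore expected in this assay rather than no change. The match is only partial, since ((1-methyl-1H-pyrazol-5-yl)carbonyl)oxy has not itself been measured here, so the range stays wide. The expected step is a 2.2-fold higher number from compound 2 to compound 3 (0.34 log units; beyond the scatter) as an estimate only. Compound 3 is estimated at 9500 nM with 3500 nM to 22000 nM as the expected range.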

Compound 3, concentration for 50% growth inhibition: 100000 nM
Estimate against measurement, compound 3: 11-fold (1.02 log units) below; measured number above the stated range.
By their numbers in this assay, from the lowest: compound 2; then compound 1; then compound 3.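

The ((1-methyl-1H-pyrazol-5-yl)carbonyl)oxy group at this chain end gives a 23-fold higher number from compound 2 to compound 3 (1.36 log units; beyond the scatter) in this assay, so the position is more sensitive to change than a 3.0-fold lower number from compound 1 to compound 2 (0.47 log units; beyond the scatter) alone could show. A carbonyl does not settle the number by itself: compound 1 and compound 3 both carry one, yet replacing methyl((1-methyl-1H-pyrazol-5-yl)carbonyl)amino with ((1-methyl-1H-pyrazol-5-yl)carbonyl)oxy gives a 7.8-fold higher number from compound 1 to compound 3 (0.89 log units; beyond the scatter), which shows that the link between carbonyl and chain also counts. No measurement at hand gives a cause for either step.

Open remains how a secondary amide carrying the amide hydrogen, or a plain ether, would stand at this chain end, and such groups would help separate the part played by the nitrogen from that of its methyl group. Also open, as far as these compounds go, is whether the order of compound 2, compound 1 and compound 3 holds with a phenyl ring in place of the 1-methyl-1H-pyrazol-5-yl group, or with a shorter chain.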